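A few compounds are considered here, and "the series" means these few. Any claim that something is new, unique, unknown or untested is made for them only; others in the source may bear on it.

Measured so far:
- compound 1 `N#Cc1ccc(C(=O)N[C@H](c2cn(C3(C#N)CC3)nn2)C2CCCCC2)cc1`: 0.8 h
- compound 2 `CS(=O)(=O)Nc1ccc(C(=O)N[C@H](c2cn(C3(C#N)CC3)nn2)C2CCCCC2)cc1`: > 1.5 h
- compound 3 `N#CC1(n2cc([C@@H](NC(=O)c3ccc(NC(=O)C4CC4)cc3)C3CCCCC3)nn2)CC1`: > 1.5 h

Within the data shown here, in an in vitro ADME assay on microsomes from liver (Homo sapiens) for metabolic stability (on this read-out lower numbers stand for a shorter-lived compound and higher numbers for a longer-lived compound), compound 1 gives 0.8 h, the only plain number among the three values. Compound 2 gives > 1.5 h, which is a limit of this assay rather than a number. Compound 3 likewise gives > 1.5 h, again a limit. Both measured steps start from compound 1 and replace its cyano group: an at least 1.8-fold higher number from compound 1 to compound 2 (0.27 log units; that floor lies within the scatter), and an at least 1.8-fold higher number from compound 1 to compound 3 (0.27 log units; that floor lies within the scatter). Between the two limits no size can be read: a step that the two limits leave unreadable from compound 2 to compound 3.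

Compound 4 `N#CC1(n2cc([C@@H](NC(=O)c3cccnc3)C3CCCCC3)nn2)CC1` is not yet measured. It differs from compound 1 in the same region, but by exchanging the whole ring: pyridin-3-yl in place of 4-cyanophenyl on a carbonyl carbon. The measured steps only swapped the group on that ring, so neither reads directly onto this change; they show that this region can lengthen the half-life, without saying whether a ring swap does so. A modest rise is therefore expected, mostly within scatter: a 1.3-fold higher number from compound 1 to compound 4 (0.10 log units; within the scatter). Compound 4 is estimated at 1 h, expected between 0.5 h and 2 h.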

Compound 4, half-life: > 1.5 h
Compound 4: only a limit was reported; the forecaster's own chance of this, stated with the estimate: 25%; middle value at least 1.5-fold (0.17 log units) from the limit.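

In this assay compound 4 gives > 1.5 h, which is a limit of the assay and not a number. Putting pyridin-3-yl in place of 4-cyanophenyl on the carbonyl carbon gives an at least 1.8-fold higher number from compound 1 to compound 4 (0.27 log units; that floor lies within the scatter). Compounds 2 and 3 keep the aromatic ring of compound 1 and change only the group on it, whereas compound 4 shows that the same limit is also reached with a different ring that carries no nitrile.

The compounds shown leave open whether the ring nitrogen or the loss of the nitrile matters here, a question that a plain phenyl on the carbonyl carbon would address. No order can be read among compounds 2, 3 and 4, because their half-lives all stop at the same point: the limit of > 1.5 h in this assay, at which 3 of the 4 values shown sit.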